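Swapping a dimethylmorpholine chain end for methoxy

A few compounds are considered here, and "the series" means these few. Any claim that something is new, unique, unknown or untested is made for them only; others in the source may bear on it.

Compound 1 `COc1cc2ncnc(-n3nc(-c4ccccn4)nc3N)c2cc1[N+](=O)[O-]`: > 13000 nM
Compound 2 `COc1cc2ncnc(-n3nc(-c4ccccn4)nc3N)c2cc1OCCCN1CC(C)OC(C)C1`: > 25000 nM

In an ADME assay on BJ cells (Homo sapiens) for cytotoxicity, with a stated time of 72 h (on this read-out lower numbers stand for an effect already at smaller amounts and higher numbers for an effect only at larger amounts of compound), compound 2 stands only at a limit, > 25000 nM, and this is not a true number. Compound 1 also gives only a limit, > 13000 nM. Neither compound has a measured value, so there is no firm point from which to count.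

Compound 3 `COCCOc1cc2c(-n3nc(-c4ccccn4)nc3N)ncnc2cc1OC` keeps the shared core and differs from compound 2 at the end of the side chain: methoxy in place of (2,6-dimethylmorpholin-4-yl)methyl on a saturated chain carbon, two bonds along the chain from an oxygen on an aromatic ring. In words, methoxy takes the place of (2,6-dimethylmorpholin-4-yl)methyl on a saturated chain carbon, two bonds along the chain from an oxygen on an aromatic ring.

Going by the values given here, only one measured step bears on this change, and it involves the same side chain: a step that the two limits leave unreadable from compound 1 to compound 2. Its size cannot be read, so it offers no guide to size or direction. Resting on the limit of compound 2, > 25000 nM, no step beyond the usual scatter is expected in this assay, and neither direction is favoured. The expected step is a number no higher from compound 2 to compound 3 (the limit leaves the size open). For compound 3 the estimate is 25000 nM, with an expected range of 10000 nM to 60000 nM.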

Compound 3, half-maximal effective concentration: > 13000 nM
Compound 3 gave a limit, no number (the forecaster's own chance of this, stated with the estimate: 75%); the middle value does not contradict the limit.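

In this assay, compound 3 gives only a limit, not a number, as do compound 1 and compound 2, and no step among these three compounds can be read. Going by these compounds, it stays open at what concentration each compound would reach this effect, and whether 2-methoxyethoxy in place of 3-(2,6-dimethylmorpholin-4-yl)propoxy shifts that concentration at all.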